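The compounds below may be only part of what the source reports. "The series", "measured", "known", "first", "only" and "open" are said of these compounds alone.

Measured in a physicochemical assay for lipophilicity, using the shake flask method, at pH 7.4; a higher number here means a more lipophilic compound, a lower number a more polar compound:
- compound 1, `CC(C)c1c(C(=O)NCc2ccccc2)nc(-c2ccc(F)cc2)n1CC[C@@H](O)C[C@@H](O)CC(=O)O`: 0.64
- compound 2, `Cc1ccc(CNC(=O)c2nn(-c3ccc(F)cc3)c(CC[C@@H](O)C[C@@H](O)CC(=O)O)c2C(C)C)cc1`: 0.24
- compound 3, `COc1cccc(CNC(=O)c2nc(-c3ccc(F)cc3)n(CC[C@@H](O)C[C@@H](O)CC(=O)O)c2C2CC2)c1`: 0.11

Compound 3 holds the lowest of the three numbers in this assay. Its nearest neighbour is compound 2, which sits higher by a margin that stays within the scatter of repeated measurements, so no order between compound 2 and compound 3 can be read from these two values. Compound 1 lies furthest from compound 3, higher by a margin beyond the scatter. Among the compounds with values here, no pair of these three compounds differs in a single place, so no step between measured compounds is available as a guide.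

Compound 4, `O=C(O)C[C@H](O)C[C@H](O)CCn1c(-c2ccc(F)cc2)nc(C(=O)NCc2ccc(F)cc2)c1C1CC1`, is not yet measured in this assay. It is built from compound 3 by one change:

4-fluorophenyl in place of 3-methoxyphenyl on a saturated chain carbon bound to an amide-type nitrogen

Within the data shown here, no measured pair shows this exchange, so the expectation rests on the value of compound 3 alone. The step from compound 3 to compound 4 in this assay is estimated as a number 0.19 log units higher from compound 3 to compound 4 (within the scatter), a small shift upward, not clearly beyond the scatter. For compound 4 the expected value in this assay is 0.3, with a range from -0.1 to 0.7.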

Compound 4, distribution coefficient: 0.17
Compound 4: the middle estimate sits 0.13 log units above what was measured; the range from low to high includes it.
By their numbers in this assay, from the lowest: compounds 3, 4 and 2 (each within the scatter of the next); then compound 1.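

In this assay, within the data shown here, the exchange of 3-methoxyphenyl for 4-fluorophenyl on a saturated chain carbon bound to an amide-type nitrogen gives a number 0.06 log units higher from compound 3 to compound 4 (within the scatter), and this is the first step that isolates one place. For this pair, then, replacing 3-methoxyphenyl, which counts one hydrogen-bond acceptor, with 4-fluorophenyl, which counts none, leaves compound 3 and compound 4 without any order that can be read, so the read-out does not separate these two groups at this position on this core. Nothing available here accounts for this result.

A single pair on a single core leaves open whether the same exchange would give a similar step on the core of compound 1 or the core of compound 2, and whether the methoxy group, the fluorine or the place of either on the ring matters more, a question that 3-fluorophenyl or 4-methoxyphenyl at this position could address. On these data alone, how far this position tolerates other groups is also open, for example an aminomethyl-substituted phenyl or a longer chain such as 2-phenylethyl in place of the benzyl group.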